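The source may hold more compounds than are shown below. What is called first, only, known or untested is meant among the compounds shown, and "the series" means these compounds.

Measured so far in a functional assay on 1321-N1 cells for agonist activity at P2Y purinoceptor 2 (Homo sapiens), read by scintillation counting and inositol phosphate accumulation; a lower number here means that less compound is needed, a higher number that more compound is needed for the effect:
- compound 1, `O=C(O)CCCO/N=c1/ccn([C@@H]2O[C@H](COP(=O)(O)OP(=O)(O)OP(=O)(O)O)[C@@H](O)[C@H]2O)c(=O)[nH]1`: 299 nM
- compound 2, `O=c1[nH]/c(=N\OCCCc2ccc(I)cc2)ccn1[C@@H]1O[C@H](COP(=O)(O)OP(=O)(O)OP(=O)(O)O)[C@@H](O)[C@H]1O`: 187 nM
- compound 3, `O=c1[nH]/c(=N\OCCCc2ccc([N+](=O)[O-])cc2)ccn1[C@@H]1O[C@H](COP(=O)(O)OP(=O)(O)OP(=O)(O)O)[C@@H](O)[C@H]1O`: 458 nM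

Compound 3 gives the highest number of the three in this assay; the gap to compound 1 is within the scatter, whereas the gap to compound 2 is beyond it, as the step of a 2.4-fold higher number from compound 2 to compound 3 (0.39 log units; beyond the scatter) shows. Going by the values given here, the two steps from the carboxy-bearing compound 1, a 1.6-fold lower number from compound 1 to compound 2 (0.20 log units; within the scatter) and a 1.5-fold higher number from compound 1 to compound 3 (0.19 log units; within the scatter), both stay within the scatter, so the only change in this assay that registers is the swap of nitro for iodo on the aromatic carbon.

Compound 4, `O=c1[nH]/c(=N\OCCCc2ccc3ccccc3c2)ccn1[C@@H]1O[C@H](COP(=O)(O)OP(=O)(O)OP(=O)(O)O)[C@@H](O)[C@H]1O`, carries the change (naphthalen-2-yl in place of 4-nitrophenyl on a saturated chain carbon, three bonds along the chain from an oxygen). Among the compounds with values here, no measured step covers this exact exchange. The nearest bearing is the step of a 2.4-fold higher number from compound 2 to compound 3 (0.39 log units; beyond the scatter): removing the nitro group brought the number down, and compound 2, whose aromatic group likewise carries no hydrogen-bond acceptors, sits lowest of the three. On that basis a modest lower number is expected for compound 4, of about the size seen between compound 2 and compound 3, with the estimate a 2.1-fold lower number from compound 3 to compound 4 (0.32 log units; beyond the scatter). Compound 4 is therefore estimated at 220 nM in this assay, in the range 90 nM to 550 nM.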

Compound 4, half-maximal effective concentration: 139 nM
Beside the measured number, compound 4's estimate is 1.6-fold (0.20 log units) above it, and the stated range covers the measured number.
By their numbers in this assay, from the lowest: compounds 4, 2, 1 and 3 (each within the scatter of the next, the first and the last beyond it).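

In this assay, putting naphthalen-2-yl in place of 4-nitrophenyl on a saturated chain carbon, three bonds along the chain from an oxygen, gives a step beyond the scatter (a 3.3-fold lower number from compound 3 to compound 4 (0.52 log units; beyond the scatter)), so this position responds to an exchange of the whole aromatic group and not only to the swap of nitro for iodo. Naphthalen-2-yl is also the first group here to separate from carboxy (a 2.2-fold lower number from compound 1 to compound 4 (0.33 log units; beyond the scatter)), whereas 4-iodophenyl and 4-nitrophenyl both stayed within the scatter of it, yet it cannot be told apart from 4-iodophenyl (a 1.3-fold lower number from compound 2 to compound 4 (0.13 log units; within the scatter)). No supporting measurement on hand accounts for these differences.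

The compounds shown leave open whether a plain phenyl or naphthalen-1-yl on the same chain would group with compound 2 and compound 4 or with compound 3, and whether an amine in place of the nitro group on the 4-nitrophenyl ring would shift the number. They also leave open whether a shorter or longer chain carrying naphthalen-2-yl would keep the number of compound 4.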